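The compounds below may be only part of what the source reports. "The series", "measured", "known", "first", "only" and "open" are said of these compounds alone.

The compounds here share one core. Compound 1 `Cn1c(=O)c2c(nc(CCSc3cccc(Br)c3)n2C)n(C)c1=O` is tested in an in vitro assay on cells for inhibition of Amine oxidase [flavin-containing] A (Homo sapiens), read by coupled enzyme assay, with a stated time of 20 min (on this read-out higher numbers stand for weaker inhibition and lower numbers for stronger inhibition), where compound 1 gives 372000 nM, the higher of the two numbers at hand. Compound 3 `Cn1c(=O)c2c(nc(COc3ccc(Br)cc3)n2C)n(C)c1=O` gives 10700 nM in this assay, a gap that lies beyond the scatter. Compound 2 `Cn1c(=O)c2c(nc(COc3cccc(Cl)c3)n2C)n(C)c1=O` is reported in this assay as "not active" (no number reported), with no number.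

Compound 4 `Cn1c(=O)c2c(nc(CCSc3ccc(Br)cc3)n2C)n(C)c1=O` has the same atoms as compound 1, joined differently: 4-bromophenyl in place of 3-bromophenyl on a sulfur. Among the compounds with values here, no pair of measured compounds differs by that change alone, so its size is open. Among the measured compounds, the one with a 4-bromophenyl carries the lower number, and a similar, modest move toward a lower number is expected from compound 1 to compound 4, as a 2.5-fold lower number from compound 1 to compound 4 (0.39 log units; beyond the scatter). Compound 4 is therefore estimated at 150000 nM, between 30000 nM and 600000 nM.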

Compound 4, half-maximal inhibitory concentration: 117000 nM
For compound 4 the middle estimate is 1.3-fold (0.11 log units) above the measured one; measured number inside the range.
By their numbers in this assay, from the lowest: compound 3; then compound 4; then compound 1.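

In this assay the swap of 3-bromophenyl for 4-bromophenyl on a sulfur gives a 3.2-fold lower number from compound 1 to compound 4 (0.50 log units; beyond the scatter) and so the placing of the bromine on this ring does register, though only modestly. Even so, compound 4 stays a weak inhibitor at 117000 nM on this read-out. Nothing at hand explains the step.

Still open, on these data alone, is whether the same swap moves the number similarly when the ring hangs on an oxygen instead of a sulfur. As far as these compounds go, how a 4-aminophenyl or a longer chain on the sulfur would read is also open.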